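The source may hold more compounds than are shown below. What is called first, only, known or untested is meant among the compounds shown, and "the series" means these compounds.

Working notes on the series. Within the data shown here, compound 1 `c1ccc(-c2ccc3c(NCCCNCc4ccco4)ccnc3c2)cc1` is the reference point here: in a physicochemical assay for solubility, with a stated time of 18 h, at pH 7.4 (on this read-out lower numbers stand for lower solubility and higher numbers for higher solubility), compound 1 gives 32000 nM, the highest of the three numbers measured so far. Compound 2 `COc1ccc(F)cc1CNCCCNc1ccnc2cc(CCC(C)C)ccc12` gives 4200 nM and compound 3 `COc1ccc(F)cc1CNCCCNc1ccnc2cc(Cc3ccc(F)cc3)ccc12` gives 4200 nM, each a step beyond the scatter below compound 1. Among the measured compounds shown here, the only single-point step among the measured compounds is no change at the digits printed from compound 2 to compound 3 (within the scatter), and it shows nothing beyond the scatter.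

Compound 4 `Cc1cc(C)cc(Cc2ccc3c(NCCCNCc4ccco4)ccnc3c2)c1` is not yet measured. It differs from compound 1 in one place: 3,5-dimethylbenzyl in place of phenyl on an aromatic carbon. For the measured compounds named here, no measured step touches this position of the core of compound 1 directly; the step from compound 2 to compound 3 concerns a group on a saturated chain carbon and only indicates that a swap of that kind on this core need not move the read-out. Compounds 2 and 3, which carry such saturated-chain groups on the core and sit well below compound 1, carry a different amine side chain as well, so their values cannot be attributed to that position alone. A moderate downward step is therefore expected, a 2.3-fold lower number from compound 1 to compound 4 (0.36 log units; beyond the scatter), with wide uncertainty. The estimate for compound 4 in this assay is 14000 nM, expected to fall between 4000 nM and 40000 nM.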

Compound 4, solubility: 4200 nM
The estimate for compound 4 lay 3.3-fold (0.52 log units) above the measured number; low and high end bracket the measured number.
By their numbers in this assay, from the lowest: compounds 2, 3 and 4 (each within the scatter of the next); then compound 1.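

In this assay, replacing phenyl with 3,5-dimethylbenzyl on an aromatic carbon of the shared core gives a 7.6-fold lower number from compound 1 to compound 4 (0.88 log units; beyond the scatter), with the amine side chain unchanged. The only earlier step, no change at the digits printed from compound 2 to compound 3 (within the scatter), concerned a group on a saturated chain carbon and did not move the read-out, so this is the first single-place change shown to do so, and it establishes that this position on the core of compound 1 is not silent. No measurement at hand accounts for the size of this step.

Among these compounds, the single step does not separate the contribution of the benzyl carbon from that of the two methyl groups. On these data alone, how plain benzyl, or a group such as an amine or a carboxylic acid at this position, would read in this assay remains open.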